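A few compounds are considered here, and "the series" means these few. Any claim that something is new, unique, unknown or untested is made for them only; others in the source may bear on it.

Compound 1, `CCOCCOc1nc(C(C)(C)C)ccc1CNC(=O)C(C)c1ccc(NS(C)(=O)=O)c(F)c1` — 23.9 nM
Compound 2, `CC(C(=O)NCc1ccc(C(C)(C)C)nc1OCc1ccccc1)c1ccc(NS(C)(=O)=O)c(F)c1` — 4.4 nM

In an assay on cells for antagonist activity at transient receptor potential cation channel subfamily V member 1 (Homo sapiens), read by FLIPR and calcium flux, with a stated time of 6 min (on this read-out lower numbers stand for stronger inhibition and higher numbers for weaker inhibition), compound 2 holds the lowest of the two numbers shown. For the measured compounds named here, the nearest is compound 1, and the only step in the set, a 5.4-fold lower number from compound 1 to compound 2 (0.73 log units; beyond the scatter), lies beyond the scatter. That step concerns the group on the saturated chain carbon bound to the ring oxygen, phenyl in place of ethoxymethyl, and says nothing directly about substituents on the phenyl itself.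

Compound 3, `CC(C(=O)NCc1ccc(C(C)(C)C)nc1OCc1ccc(F)cc1)c1ccc(NS(C)(=O)=O)c(F)c1`, differs from compound 2 by fluoro in place of hydrogen on an aromatic carbon of the six-membered aromatic ring of carbon only, para to a large group. Going by the values given here, no measured pair varies that ring, so the one measured step bears on it only indirectly, showing that the benzyloxy arrangement is well tolerated. Among the compounds with values here, with no direct precedent, a small change either way is the most that can be expected. The expected step is a 1.0-fold higher number from compound 2 to compound 3 (0.01 log units; within the scatter), within the scatter. In this assay compound 3 is expected at 4.5 nM, with a range from 1.5 nM to 13 nM.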

Compound 3, inhibition constant: 0.8 nM
The estimate for compound 3 lay 5.6-fold (0.75 log units) above the measured number; the whole stated range lies above it.
By their numbers in this assay, from the lowest: compound 3; then compound 2; then compound 1.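

In this assay, the phenyl of the benzyloxy group responds to substitution: fluoro in place of hydrogen on an aromatic carbon, para to a large group, gives a 5.5-fold lower number from compound 2 to compound 3 (0.74 log units; beyond the scatter), so this single added atom matters at this position, which the earlier step could not show. Taken against the ethoxymethyl group, 4-fluorophenyl gives a 30-fold lower number from compound 1 to compound 3 (1.48 log units; beyond the scatter), a large step that places compound 3 lowest of the three compounds on this read-out, with its steps to both others beyond the scatter. Nothing available explains why the fluoro substituent changes the number at this position.

The compounds shown leave open whether this step is particular to fluoro or would also appear with chloro, methyl or methoxy in the same place, and whether fluoro elsewhere on that ring would give a similar number. Also open, going by these compounds, is whether the 4-fluorophenyl group would hold its value with a longer chain linking it to the oxygen, as only the single-carbon benzyl link appears here.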